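The source may hold more compounds than are shown below. What is called first, only, known or untested is meant among the compounds shown, and "the series" means these compounds.

Compound 3 `CNC(=O)CCc1ccncc1-c1ccc2ccccc2c1` is known in a functional assay on KB cells (Homo sapiens) for inhibition, read by sulforhodamine B assay, with a stated time of 72 h (a lower number here means a stronger inhibitor of growth, a higher number a weaker inhibitor of growth), only by a limit of the assay, > 10000 nM. Compound 1 `NC(=O)/C=C/c1ccncc1-c1ccc2ccccc2c1` likewise gives in this assay a limit, > 10000 nM. Compound 2 `CNC(=O)/C=C/c1ccncc1-c1ccc2[nH]ccc2c1` also gives in this assay a limit, > 10000 nM. Among the measured compounds shown here, the one single-point step measured, a step that the two limits leave unreadable from compound 1 to compound 3, is therefore unreadable, and all three values share the same footing: the limit of > 10000 nM in this assay, at which 3 of the 3 values shown sit. Compound 4 `COC(=O)/C=C/c1ccncc1-c1ccc2ccccc2c1` differs from compound 3 by 2-(methoxycarbonyl)ethenyl in place of 2-(methylcarbamoyl)ethyl on an aromatic carbon. For the measured compounds named here, no measured step bears readably on this change, so no direction can be drawn from the data, and the most that can be expected is that compound 4 also sits at the limit. Compound 4 is estimated at 15000 nM, within 5000 nM to 50000 nM. The expected step is a step that the limit leaves unreadable from compound 3 to compound 4.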

Compound 4, concentration for 50% growth inhibition: 6730 nM
Compound 4: middle estimate off by 2.2-fold (0.35 log units), on the high side, within the range that was stated.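

Compound 4 alone among the compounds shown gives a number in this assay rather than a limit: the limit of > 10000 nM in this assay, at which 3 of the 4 values shown sit. Among the compounds shown here, with the ester on the same unsaturated chain, the single change on the carbonyl gives an at least 1.4-fold lower number from compound 1 to compound 4 (0.17 log units; that floor lies within the scatter), and the full exchange of the group gives an at least 1.4-fold lower number from compound 3 to compound 4 (0.17 log units; that floor lies within the scatter). For the compounds shown here, both steps therefore show only that a methoxycarbonyl-bearing group at this place can bring a reading within the assay's range, not that it clearly lowers the number.

Still open, going by these compounds, are the true sizes of both steps and whether a carboxylic acid or the saturated 2-(methoxycarbonyl)ethyl group at this place would also give a reading.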